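From a chloro to a methoxy on the benzyl ring

The source may hold more compounds than are shown below. What is called first, only, known or untested is meant among the compounds shown, and "the series" means these compounds.

Of the compounds shown here, three have been measured in an assay on membranes from liver for displacement of a labelled ligand from Sigma non-opioid intracellular receptor 1 (Rattus norvegicus), read by scintillation counting; a lower number here means a stronger inhibitor, a higher number a weaker inhibitor. Compound 1 `COc1ccc(CN(C)CCCn2c(=O)oc3ccccc32)cc1` gives 83 nM. Compound 2 `CN(CCCCn1c(=O)oc2ccccc21)Cc1cccc(Cl)c1` gives 302 nM. Compound 3 `CN(CCCn1c(=O)oc2ccccc21)Cc1ccc(Cl)cc1` gives 1150 nM. Compound 2 thus holds the second highest of the three numbers, with its gap to compound 1 and its gap to compound 3 each beyond the scatter.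

Compound 4 `COc1ccccc1CN(C)CCCCn1c(=O)oc2ccccc21` differs from compound 2 in one place: 2-methoxyphenyl in place of 3-chlorophenyl on a saturated chain carbon bound to an amine nitrogen. One measured step of a single change bears on this: a 14-fold higher number from compound 1 to compound 3 (1.14 log units; beyond the scatter), where a chloro replaced a methoxy on an aromatic carbon and the number rose sharply. The change to compound 4 runs the other way, a methoxy entering where a chloro leaves, though the ring names differ from those of compound 1 and compound 3, so the size is uncertain. For compound 4 the expected step is a 3.0-fold lower number from compound 2 to compound 4 (0.48 log units; beyond the scatter), toward a lower number in this assay. Compound 4 is therefore estimated at 100 nM, with a range from 30 nM to 400 nM.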

Compound 4, inhibition constant: 594 nM
The estimate for compound 4 lay 5.9-fold (0.77 log units) below the measured number; measured number above the stated range.
By their numbers in this assay, from the lowest: compound 1; then compounds 2, 4 and 3 (each within the scatter of the next, the first and the last beyond it).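

In this assay the swap of 3-chlorophenyl for 2-methoxyphenyl gives a 2.0-fold higher number from compound 2 to compound 4 (0.29 log units; within the scatter) and so, at this place on a saturated chain carbon bound to an amine nitrogen, the data do not tell the two groups apart. The large step of a 14-fold higher number from compound 1 to compound 3 (1.14 log units; beyond the scatter) therefore does not hold as a general rule for exchanging chloro and methoxy, as that exchange has a clear effect in one pair and none that can be read in the other. No measurement at hand explains this contrast.

From the compounds shown here alone, the two pairs differ in more than the swap itself, so what separates them stays open. A 3-methoxyphenyl or a 2-chlorophenyl on the chain shared by compound 2 and compound 4 would show whether the group's place on the ring matters here.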